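The source may report more compounds than this note shows. Statements on the series, on what has been measured and on what is new or still open speak of the compounds shown alone.

Series of three measured compounds on one shared core. Compound 1 `Clc1ccc(CO/N=C/c2c(-c3cccc4ccccc34)nc3sccn23)cc1Cl` gives 940 nM in an assay on HepG2 cells for agonist activity at nuclear receptor subfamily 1 group I member 3 (Homo sapiens), read by a luciferase reporter, with a stated time of 23 h; a lower number here means that less compound is needed, a higher number that more compound is needed for the effect. Compound 2 `Clc1cccc(-c2nc3sccn3c2/C=N/OCc2ccc(Cl)c(Cl)c2)c1` gives 1100 nM in this assay. Compound 3 `CC(C)c1ccc(-c2nc3sccn3c2/C=N/OCc2ccc(Cl)c(Cl)c2)cc1` gives 590 nM in this assay. Compound 3 stands at the lowest of the three numbers, yet the steps of a 1.6-fold lower number from compound 1 to compound 3 (0.20 log units; within the scatter) and a 1.9-fold lower number from compound 2 to compound 3 (0.27 log units; within the scatter) both fall within the scatter, as does a 1.2-fold higher number from compound 1 to compound 2 (0.07 log units; within the scatter), so the three compounds cannot be ranked against each other.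

Compound 4 `Clc1ccc(CO/N=C/c2c(-c3ccccc3)nc3sccn23)cc1Cl` differs from compound 3 by hydrogen in place of isopropyl on an aromatic carbon of a six-membered aromatic ring of carbon only, para to a large group; cut one bond further out, the change reads 4-isopropylphenyl to phenyl. Within the data shown here, no measured step removes a group from this ring. The nearest steps exchange the whole aryl group, a 1.6-fold lower number from compound 1 to compound 3 (0.20 log units; within the scatter) and a 1.9-fold lower number from compound 2 to compound 3 (0.27 log units; within the scatter), and neither leaves the scatter. Exchanges of this aryl group have moved this assay little, so the step to compound 4 is expected to remain within the scatter, with a slight lean toward a higher number. The expected step is a 1.5-fold higher number from compound 3 to compound 4 (0.18 log units; within the scatter). Compound 4 is expected to give 900 nM in this assay, with a range from 400 nM to 2000 nM.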

Compound 4, half-maximal effective concentration: 580 nM
Estimate against measurement, compound 4: 1.6-fold (0.19 log units) above; low and high end bracket the measured number.
By their numbers in this assay, from the lowest: compounds 4, 3, 1 and 2 (each within the scatter of the next).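

In this assay, taking the substituent off the ring altogether, with hydrogen in place of isopropyl, gives a 1.0-fold lower number from compound 3 to compound 4 (0.01 log units; within the scatter), so at this place, para to a large group, the isopropyl carries no readable weight in the number. The bare phenyl also stays within the scatter of the other two aryl groups, with hydrogen in place of chloro giving a 1.9-fold lower number from compound 2 to compound 4 (0.28 log units; within the scatter) and phenyl in place of naphthalen-1-yl giving a 1.6-fold lower number from compound 1 to compound 4 (0.21 log units; within the scatter), so the four compounds still cannot be ranked and this aryl position is flat across everything from a bare phenyl to naphthalen-1-yl. Nothing at hand accounts for this flatness.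

All the groups shown at this position are carbon-based aryl groups, bare or bearing chloro or isopropyl, so it remains open whether an amine or a carboxylic acid on the phenyl, or a small alkyl such as methyl in place of the whole aryl group, would stay equally flat. The dichlorobenzyl oxime ether is common to all four compounds, which leaves open how far the number depends on that part of the molecule.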